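The source may hold more compounds than are shown below. What is called first, only, known or untested is meant among the compounds shown, and "the series" means these compounds.

In a functional assay on A2780 cells (Homo sapiens) for cytotoxicity, read by sulforhodamine B assay, with a stated time of 72 h (a higher number here means a weaker inhibitor, a lower number a stronger inhibitor), three compounds that share a core and differ in the group on the sulfonyl sulfur have been measured. Compound 1 (`O=C(NCc1ccc(S(=O)(=O)c2cncc(C(F)(F)F)c2)cc1)N1Cc2ccncc2C1`) gives 10 nM. Compound 2 (`O=C(NCc1ccc(S(=O)(=O)C2CCC(F)(F)CC2)cc1)N1Cc2ccncc2C1`) gives 13 nM, and a 1.3-fold higher number from compound 1 to compound 2 (0.11 log units; within the scatter) separates the two. Compound 3 (`O=C(NCc1ccc(S(=O)(=O)N2CCOCC2)cc1)N1Cc2ccncc2C1`) gives 68 nM, the highest number of the three, closest to compound 2 and furthest from compound 1.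

Next is compound 4 (`O=C(NCc1ccc(S(=O)(=O)N2CCC(O)CC2)cc1)N1Cc2ccncc2C1`), with 4-hydroxypiperidin-1-yl in place of morpholin-4-yl on a sulfonyl sulfur. Among the measured compounds shown here, no measured compound carries this group, so the evidence is indirect. The relevant steps are a 6.8-fold higher number from compound 1 to compound 3 (0.83 log units; beyond the scatter) and a 5.2-fold higher number from compound 2 to compound 3 (0.72 log units; beyond the scatter), both modest and both entering morpholin-4-yl. These suggest that replacing morpholin-4-yl could lower the number, though neither step starts from a comparable group, so a step of similar size is not assumed. The expected change is smaller, a 1.7-fold lower number from compound 3 to compound 4 (0.23 log units; within the scatter), towards a lower number. For compound 4 the estimate is 40 nM, with an expected range of 15 nM to 110 nM.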

Compound 4, half-maximal inhibitory concentration: 98 nM
The estimate for compound 4 lay 2.5-fold (0.39 log units) below the measured number; low and high end bracket the measured number.
By their numbers in this assay, from the lowest: compounds 1 and 2 (each within the scatter of the next); then compounds 3 and 4 (each within the scatter of the next).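

In this assay the exchange of morpholin-4-yl for 4-hydroxypiperidin-1-yl on the sulfonyl sulfur gives a 1.4-fold higher number from compound 3 to compound 4 (0.16 log units; within the scatter) and so brings in a hydrogen-bond donor without separating the two groups in this assay. The gap to the other two compounds remains, with a 7.5-fold higher number from compound 2 to compound 4 (0.88 log units; beyond the scatter) and with a 9.8-fold higher number from compound 1 to compound 4 (0.99 log units; beyond the scatter), so the gap first seen with morpholin-4-yl now also holds for a second group joined to the sulfur through a ring nitrogen. Nothing available bears on the cause of this gap.

Still open, as far as these compounds go, is whether the ring nitrogen on the sulfur accounts for the gap on its own, as 4,4-difluorocyclohexyl and 5-(trifluoromethyl)pyridin-3-yl also differ from both groups elsewhere. A plain piperidin-1-yl, or a cyclohexyl ring carrying a hydroxyl group, on the sulfonyl sulfur would bear on that question.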